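Swapping bromo for methoxy on two related cores

The source may report more compounds than this note shows. Statements on the series, on what has been measured and on what is new or still open speak of the compounds shown alone.

Compound 1 `CCCNNC(=O)c1ccc(CNC(=O)c2cc3cc(Br)ccc3[nH]2)cc1` gives > 10000 nM in an assay on isolated protein for inhibition of protein deacetylase HDAC6 (Homo sapiens), read by fluorescence, with a stated time of 2 h (a lower number here means a stronger inhibitor, a higher number a weaker inhibitor), and this is a limit of the assay rather than a number.
Compound 2 `CCCNNC(=O)c1ccc(CNC(=O)c2cc3cc(OC)ccc3[nH]2)cc1` gives > 10000 nM in this assay, again a limit rather than a number.
Compound 3 `CCCNNC(=O)c1ccc(CNC(=O)c2cc3cc(Br)ccc3o2)cc1` gives > 10000 nM in this assay, also a limit rather than a number.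

Compounds 1 and 2 share one core and differ only by methoxy in place of bromo on an aromatic carbon. Because both sit at the limit, the step that the two limits leave unreadable from compound 1 to compound 2 cannot be read from these data. Compound 3 carries the other core; the difference between the two cores is not broken down here, so the two measured pairs are related only through the shared substitution.

The compound that has not yet been measured is compound 4 `CCCNNC(=O)c1ccc(CNC(=O)c2cc3cc(OC)ccc3o2)cc1`. Among the compounds with values here, it differs from compound 3 by methoxy in place of bromo on an aromatic carbon, which is the same change, at the same place, as the one made between compound 1 and compound 2.

What can be said about the outcome rests on (the limit of > 10000 nM in this assay, at which 3 of the 3 values shown sit). Within the data shown here, every compound measured in this assay so far has returned only a limit, and the one time the bromo-to-methoxy change was made it did not lift its product off that limit. The step from compound 3 to compound 4 is therefore expected to be a step that the limit leaves unreadable from compound 3 to compound 4. Compound 4 is expected to come out near 20000 nM, with a plausible span from 5000 nM to 100000 nM, and most likely to be reported again only as a limit.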

Compound 4, half-maximal inhibitory concentration: > 10000 nM
Compound 4 gave a limit, no number; the forecaster's own chance of this, stated with the estimate: 85%; the middle value is on the limit's open side.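

Compound 3 and compound 4 each gave only a limit and no number in this assay, so no step can be read between them, and the whole set shares that result: the limit of > 10000 nM in this assay, at which 4 of the 4 values shown sit.

The compounds shown leave open how strong any of them really is, and whether methoxy in place of bromo on an aromatic carbon changes that strength on either core.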